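The source may hold more compounds than are shown below. What is called first, only, known or untested is meant among the compounds shown, and "the series" means these compounds.

Working notes on the series. Compound 3 `ClCc1ccc(Cn2cnc3c(Cl)nc(Cl)nc32)cc1` and compound 1 `ClCc1ccc(Cn2cnc3c(Cl)ncnc32)cc1` share a core; compound 2 `ClCc1ccc(Cn2cnc3nc(Cl)nc(Cl)c32)cc1` has the same atoms as compound 3 joined differently, and the difference between the two cores is not broken down here. In a functional assay on SNB-19 cells (Homo sapiens) for cytotoxicity, read by sulforhodamine B assay, with a stated time of 48 h (a higher number here means a weaker inhibitor of growth, a lower number a stronger inhibitor of growth), compound 3 gives 2510 nM, and compound 1 gives 3630 nM; the step of a 1.4-fold higher number from compound 3 to compound 1 (0.16 log units; within the scatter) is a change of hydrogen in place of chloro on an aromatic carbon. In this assay compound 2 gives 29500 nM, the highest number of the three measured.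

Compound 4 `ClCc1ccc(Cn2cnc3ncnc(Cl)c32)cc1` is not yet measured in this assay. It differs from compound 2 by hydrogen in place of chloro on an aromatic carbon, the same change as that from compound 3 to compound 1, made on the core of compound 2. The step from compound 2 to compound 4 is expected to be of about the size seen from compound 3 to compound 1, that is a 1.2-fold higher number from compound 2 to compound 4 (0.07 log units; within the scatter), because the measured step of a 1.4-fold higher number from compound 3 to compound 1 (0.16 log units; within the scatter) lies within the scatter. The estimate for compound 4 in this assay is therefore 35000 nM, with an expected range from 12000 nM to 100000 nM.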

Compound 4, concentration for 50% growth inhibition: 1690 nM
Compound 4: middle estimate off by 21-fold (1.32 log units), on the high side; measured number below the stated range.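

In this assay, hydrogen in place of chloro on an aromatic carbon between two ring nitrogen atoms gives a 17-fold lower number from compound 2 to compound 4 (1.24 log units; beyond the scatter), and this step does not match the one seen on the core of compound 3: the same change on two cores in this assay, a 1.4-fold higher number (0.16 log units; within the scatter) from compound 3 to compound 1 and a 17-fold lower number (1.24 log units; beyond the scatter) from compound 2 to compound 4, 25-fold (1.40 log units) apart, beyond the scatter of two such steps. For these two pairs, the size of the step depends on the core, so a step measured on one core cannot be carried over to the other as a number. For the compounds shown here, this rests on only two pairs in a single cell line, and it does not show what sets the two cores apart or how the change would behave on any third core.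

As far as these compounds go, it remains open whether an amine or a methoxy group on that same aromatic carbon would give a step as large as the one on the core of compound 2 or one as small as the one on the core of compound 3. From the compounds shown here alone, it is also open whether the gap between the two steps would persist in other cell lines.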